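A few compounds are considered here, and "the series" means these few. Any claim that something is new, unique, unknown or untested is made for them only; others in the source may bear on it.

Measured in a functional assay on U-87MG ATCC cells for cytotoxicity against U-87 MG (Homo sapiens), read by MTT assay, with a stated time of 72 h; on this read-out higher numbers stand for weaker inhibition and lower numbers for stronger inhibition:

Compound 1 `O=C(Nc1nc2ccc(F)cc2s1)c1cn(-c2ccccc2)nc1-c1ccc(Cl)cc1` gives 7770 nM
Compound 2 `O=C(Nc1nc2ccc(Cl)cc2s1)c1cn(-c2ccccc2)nc1-c1ccc(Cl)cc1` gives 5870 nM
Compound 3 `COc1ccc2nc(NC(=O)c3cn(-c4ccccc4)nc3-c3ccc(Cl)cc3)sc2c1` gives 21200 nM

Compound 3 stands highest of the three, that is weakest: a 2.7-fold higher number from compound 1 to compound 3 (0.44 log units; beyond the scatter) and a 3.6-fold higher number from compound 2 to compound 3 (0.56 log units; beyond the scatter) both lie beyond the scatter, while a 1.3-fold lower number from compound 1 to compound 2 (0.12 log units; within the scatter) does not. Compound 4 `COc1ccc(-c2nn(-c3ccccc3)cc2C(=O)Nc2nc3ccc(OC)cc3s2)cc1` carries a second such swap, now on the other aromatic ring: methoxy in place of chloro on an aromatic carbon. Among the measured compounds shown here, the only guidance comes from the earlier methoxy replacements, which each raised the number modestly, although they sat on a different ring, so their bearing on this change is uncertain. A further modest rise, or no change beyond the scatter, is expected. The step from compound 3 to compound 4 is estimated at a 1.9-fold higher number from compound 3 to compound 4 (0.28 log units; within the scatter), giving compound 4 an expected 40000 nM, with a range of 15000 nM to 110000 nM.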

Compound 4, half-maximal inhibitory concentration: 5890 nM
Compound 4: middle estimate off by 6.8-fold (0.83 log units), on the high side; measured number below the stated range.
By their numbers in this assay, from the lowest: compounds 2, 4 and 1 (each within the scatter of the next); then compound 3.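

In this assay, the change from 4-chlorophenyl to 4-methoxyphenyl gives a lower number (a 3.6-fold lower number from compound 3 to compound 4 (0.56 log units; beyond the scatter)), while the same swap of chloro for methoxy on the other aromatic ring gave a higher one (a 3.6-fold higher number from compound 2 to compound 3 (0.56 log units; beyond the scatter)). The outcome of this replacement therefore depends on where it is made and cannot be carried from one ring to the other. Nothing available explains this difference.

Going by these compounds, whether 4-methoxyphenyl also lowers the number with fluoro or chloro on the other ring remains open. So does how an amine or a hydroxy group would behave at this position.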